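One Methyl Removed Across Two Different Cores

The compounds below may be only part of what the source reports. "The series", "measured", "known", "first", "only" and "open" are said of these compounds alone.

Compound 1 `Cc1cnn(C(=O)N2CCCCC2)c1` and compound 2 `O=C(N1CCCCC1)n1cccn1` share a small core, while compound 3 `Cc1cnn(C(=O)N2CCCN(Cc3ccc(OCc4ccccc4)cc3)CC2)c1` and compound 4 `O=C(N1CCCN(Cc2ccc(OCc3ccccc3)cc2)CC1)n1cccn1` share a larger one; the difference between the two cores is not broken down here. In an assay on membranes from brain for binding affinity to neutral cholesterol ester hydrolase 1 (Mus musculus), read by fluorescence, with stated times of 1 h and 30 min (on this read-out lower numbers stand for stronger inhibition and higher numbers for weaker inhibition), compound 1 gives only a limit of the assay, > 100000 nM. Compound 2 likewise gives only a limit, > 100000 nM. Compound 3 also gives only a limit, > 100000 nM. The change from compound 1 to compound 2 is hydrogen in place of methyl on an aromatic carbon, and its step, a step that the two limits leave unreadable from compound 1 to compound 2, cannot be read because of the limit of > 100000 nM in this assay, at which 3 of the 3 values shown sit. The change from compound 3 to compound 4 is hydrogen in place of methyl on an aromatic carbon, the same kind of change, though here the ring atom bears a large group rather than a group of 8 heavy atoms. Compound 4 is expected to remain at the limit as well, an estimated step of a number no higher from compound 3 to compound 4 (the limit leaves the size open), resting on (the limit of > 100000 nM in this assay, at which 3 of the 3 values shown sit). Compound 4 is therefore estimated at 100000 nM.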

Compound 4, half-maximal inhibitory concentration: > 100000 nM
Compound 4 was reported as a limit; the forecaster's own chance of this, stated with the estimate: 85%; the middle value lies on the limit itself.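

No step can be read from compound 3 to compound 4, because both compounds sit at a limit of the assay: the limit of > 100000 nM in this assay, at which 4 of the 4 values shown sit.

The compounds shown leave open whether hydrogen in place of methyl changes inhibition on either core, and how strongly any of them inhibits.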